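A few compounds are considered here, and "the series" means these few. Any claim that something is new, unique, unknown or untested is made for them only; others in the source may bear on it.

Of the compounds shown here, three have so far been tested in a functional assay on RAW264.7 cells (Mus musculus) for inhibition, read by Griess assay, with stated times of 2 h and 24 h; a lower number here means a stronger inhibitor, a higher number a weaker inhibitor. Compound 1 `C#CCOc1cc(O)c2c(c1)O[C@H](c1ccc(OC)c(O)c1)C/C2=N\O` gives 19100 nM, and compound 2 `COc1ccc([C@@H]2C/C(=N\O)c3c(O)cc(OCc4cn(Cc5ccccc5C)nn4)cc3O2)cc1O` gives 18000 nM. Compound 3 `COc1ccc([C@@H]2CC(=O)c3c(O)cc(OCc4cn(Cc5ccccc5F)nn4)cc3O2)cc1O` gives 7320 nM in this assay, the lowest of the three numbers, and its gaps to compound 2 and to compound 1 both lie beyond the usual scatter, so compound 3 is the strongest inhibitor among them.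

Compound 4 `COc1ccc([C@@H]2CC(=O)c3c(O)cc(OCc4cn(Cc5cccc(C(F)(F)F)c5)nn4)cc3O2)cc1O` has not yet been measured. It differs from compound 3 in one place: 3-(trifluoromethyl)phenyl in place of 2-fluorophenyl on a saturated chain carbon bound to an aromatic nitrogen. For the measured compounds named here, no measured pair shows this change, so nothing in the data fixes its size. The step of a 1.2-fold lower number from compound 3 to compound 4 (0.09 log units; within the scatter) is expected to be small, toward a somewhat lower number, and may not exceed the scatter. Compound 4 is therefore estimated to give 6000 nM in this assay, with a range from 2500 nM to 15000 nM.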

Compound 4, half-maximal inhibitory concentration: 19900 nM
The estimate for compound 4 lay 3.3-fold (0.52 log units) below the measured number; measured number above the stated range.
By their numbers in this assay, from the lowest: compound 3; then compounds 2, 1 and 4 (each within the scatter of the next).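

The aryl group at this place, on a saturated chain carbon bound to an aromatic nitrogen, matters in this assay: 3-(trifluoromethyl)phenyl in place of 2-fluorophenyl gives a 2.7-fold higher number from compound 3 to compound 4 (0.43 log units; beyond the scatter) and thus weaker inhibition. For the compounds shown here, this is the first step in the set that changes only one place, and the group with more heavy atoms is the weaker here. No available measurement accounts for this step.

Both the substituent and its printed ring number change together, and the compounds shown do not separate the two. As far as these compounds go, how an unsubstituted benzyl group, or a benzyl group carrying an amine, would behave here also stays open.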